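The source may report more compounds than this note shows. Statements on the series, on what has been measured and on what is new or still open speak of the compounds shown alone.

Measured compounds:
compound 1 `CCCc1cc(NC2CCC2)c2cc(NC(=O)/C=C/c3ccc(C(F)(F)F)cc3)ccc2n1`, 18 nM
compound 2 `CCCc1cc(N)c2cc(NC(=O)/C=C/c3ccc(CC)cc3)ccc2n1`, 1.4 nM
compound 3 `CCCc1cc(N)c2cc(NC(=O)c3ccc(-c4ccc(Cl)cc4)cc3)ccc2n1`, 0.7 nM

In an assay on isolated protein for displacement of a labelled ligand from melanin-concentrating hormone receptor 1 (Homo sapiens) (a lower number here means a stronger inhibitor, a higher number a weaker inhibitor), compound 1 gives 18 nM, the highest of the three numbers. Compound 2 gives 1.4 nM and compound 3 gives 0.7 nM, both beyond the scatter lower than compound 1. Among the measured compounds shown here, compound 2 and compound 3 carry a free amino group where compound 1 carries cyclobutylamino, but they also differ from compound 1 in the acyl part, so no single step is isolated among the measured compounds.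

Compound 4 `CCCc1cc(N2CCCCC2)c2cc(NC(=O)/C=C/c3ccc(C(F)(F)F)cc3)ccc2n1` takes a new step from compound 1: piperidin-1-yl in place of cyclobutylamino on an aromatic carbon. For the measured compounds named here, no measured pair shows this kind of change, and nothing here separates its effect from the rest of the molecule. The step from compound 1 to compound 4 in this assay is expected to be modest, a 2.2-fold higher number from compound 1 to compound 4 (0.35 log units; beyond the scatter), toward a somewhat higher number, with wide uncertainty either way. Compound 4 is estimated at 40 nM, range 8 nM to 200 nM.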

Compound 4, half-maximal inhibitory concentration: > 4000 nM
Compound 4 gave a limit, no number; the forecaster's own chance of this, stated with the estimate: 3%; at least 100-fold (2.00 log units) between middle value and limit.
By their numbers in this assay, from the lowest: compounds 3 and 2 (each within the scatter of the next); then compound 1. At a limit, above all of these: compound 4.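

In this assay, piperidin-1-yl in place of cyclobutylamino on this aromatic carbon, opposite the ring nitrogen, gives an at least 220-fold higher number from compound 1 to compound 4 (2.34 log units; beyond the scatter). Among the compounds shown here, this position is therefore far from indifferent to the amine it carries, which the earlier compounds, differing in more than one place, could not show. The result for compound 4 is a limit, not a number: the limit of > 4000 nM in this assay, at which 1 of the 4 values shown sits.

The change swaps a four-membered ring for a six-membered one and also loses the hydrogen-bond donor, and the step does not separate the two. A cyclohexylamino group at this position would keep the donor with a six-membered ring and so pull them apart.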